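The compounds below may be only part of what the source reports. "The series", "measured", "known", "first", "only" and "open" are said of these compounds alone.

Compound 1, with the structure `COc1cc(-c2cc(/C=C/C(=O)c3ccc(N)cc3)[nH]n2)cc(OC)c1OC`, has been measured in a functional assay on SK-MEL-2 cells (Homo sapiens) for cytotoxicity, read by sulforhodamine B assay, with a stated time of 48 h, tested at 0.01 uM (on this read-out higher numbers stand for a weaker effect at the one concentration tested and lower numbers for a stronger effect), where compound 1 gives 106%. On the numbers shown, compound 1 stands highest of the three measured compounds; compound 3, the structure `COc1cc(C(=O)/C=C/c2cc(-c3cc(OC)c(OC)c(OC)c3)n[nH]2)cc(OC)c1OC`, gives 104%, which sits within the scatter of compound 1, while compound 2, the structure `COc1ccc(C(=O)/C=C/c2cc(-c3cc(OC)c(OC)c(OC)c3)n[nH]2)cc1OC`, gives 86%, a number beyond the scatter below compound 1. Compound 4 has the structure `COc1cc(-c2cc(/C=C/C(=O)c3ccc(F)c(F)c3)[nH]n2)cc(OC)c1OC` and has not yet been measured. It differs from compound 1 in one place: 3,4-difluorophenyl in place of 4-aminophenyl on a carbonyl carbon. The measured step that bears on this change is the one at the same carbonyl carbon, where a number 20 percentage points lower from compound 1 to compound 2 (beyond the scatter). A second step, a number 18 percentage points higher from compound 2 to compound 3 (beyond the scatter), shows that adding one more methoxy returned most of that loss, so the two measured aryl groups on the carbonyl carbon give numbers near that of compound 1 or modestly below it. A modest drop from compound 1 to compound 4 is therefore expected, with a change staying within the scatter also plausible: the expected step is a number 11 percentage points lower from compound 1 to compound 4 (beyond the scatter). Compound 4 is estimated to give 95% in this assay, with a range from 80% to 110%.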

Compound 4, a percentage reported as activity, at one concentration (the size of the read-out at that concentration, not a potency): 93%
Beside the measured number, compound 4's estimate is 2 percentage points above it; the measured number falls inside the stated range.
By their numbers in this assay, from the lowest: compounds 2 and 4 (each within the scatter of the next); then compounds 3 and 1 (each within the scatter of the next).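

In this assay, putting 3,4-difluorophenyl in place of 4-aminophenyl on the carbonyl carbon gives a number 13 percentage points lower from compound 1 to compound 4 (beyond the scatter), so a ring carrying fluorine instead of nitrogen joins the 3,4-dimethoxyphenyl ring of compound 2 in showing a modest shift toward a stronger effect. Exchanging the 3,4-dimethoxyphenyl ring for the 3,4-difluorophenyl ring gives a number 7 percentage points higher from compound 2 to compound 4 (within the scatter), so at this carbonyl carbon these two rings cannot be told apart, although methoxy and fluorine are very different groups. Compound 3 goes against any rule that removing 4-aminophenyl by itself lowers the number, as its value lies within the scatter of that of compound 1, and nothing shown here explains the differences among these rings.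

The compounds shown leave open how a plain phenyl ring, a ring with a single fluorine, or a ring bearing a carboxylic acid would read at this carbonyl carbon. They also leave open whether these modest shifts would persist at other concentrations, as one concentration gives the size of a read-out and not a potency.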